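Adding a Nitro Group to Compound 3

The source may report more compounds than this note shows. Statements on the series, on what has been measured and on what is new or still open speak of the compounds shown alone.

Measured in a functional assay on QGY-7703 cells (Homo sapiens) for cytotoxicity, read by MTT assay, with a stated time of 24 h; on this read-out lower numbers stand for stronger inhibition and higher numbers for weaker inhibition:
- compound 1 `O=C1/C(=C/c2cccnc2)CN(S(=O)(=O)c2ccccc2)C/C1=C\c1ccccc1F` gives 4800 nM
- compound 2 `O=C1/C(=C/c2cccnc2)CN(S(=O)(=O)c2ccc([N+](=O)[O-])cc2)C/C1=C\c1ccccc1F` gives 5600 nM
- compound 3 `O=C1/C(=C/c2ccncc2)CN(S(=O)(=O)c2ccccc2)C/C1=C\c1ccccc1F` gives 8400 nM

Compound 3, at 8400 nM, carries the highest of the three numbers, but it lies within the usual scatter of both other compounds, so these values set no firm order.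

The next compound, compound 4 `O=C1/C(=C/c2ccncc2)CN(S(=O)(=O)c2ccc([N+](=O)[O-])cc2)C/C1=C\c1ccccc1F`, departs from compound 3 by one change: nitro in place of hydrogen on an aromatic carbon. This is nitro in place of hydrogen on an aromatic carbon, para to a large group, so phenyl becomes 4-nitrophenyl.

The same change has been measured once, with pyridin-3-yl in place of pyridin-4-yl, as a 1.2-fold higher number from compound 1 to compound 2 (0.07 log units; within the scatter). That step is small and stays within the scatter. The other measured step, a 1.8-fold higher number from compound 1 to compound 3 (0.24 log units; within the scatter), is the exchange of pyridin-3-yl for pyridin-4-yl, and it too stays within the scatter. Among the measured compounds shown here, it gives no sign that the nitro change should behave differently on compound 3, though only this one pair tests the change.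

No shift beyond the scatter is therefore expected in this assay. The expected step is a 1.1-fold higher number from compound 3 to compound 4 (0.05 log units; within the scatter). For compound 4 the estimated value is 9500 nM, with an expected range of 5500 nM to 16000 nM.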

Compound 4, half-maximal inhibitory concentration: 8800 nM
Compound 4: the middle estimate sits 1.1-fold (0.03 log units) above what was measured; measured number inside the range.
By their numbers in this assay, from the lowest: compounds 1, 2, 3 and 4 (each within the scatter of the next).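

In this assay, the exchange of hydrogen for nitro now has a second reading, a 1.0-fold higher number from compound 3 to compound 4 (0.02 log units; within the scatter), showing that phenyl to 4-nitrophenyl stays within the scatter with either pyridin-3-yl or pyridin-4-yl on the shared core. The two readings of this change agree: the same change on two cores in this assay, a 1.2-fold higher number (0.07 log units; within the scatter) from compound 1 to compound 2 and a 1.0-fold higher number (0.02 log units; within the scatter) from compound 3 to compound 4, 1.1-fold (0.05 log units) apart, within the scatter of two such steps The exchange of pyridin-3-yl for pyridin-4-yl also gains a second reading, a 1.6-fold higher number from compound 2 to compound 4 (0.20 log units; within the scatter), and it too stays within the scatter whether the aromatic ring carries hydrogen or nitro: the same change on two cores in this assay, a 1.8-fold higher number (0.24 log units; within the scatter) from compound 1 to compound 3 and a 1.6-fold higher number (0.20 log units; within the scatter) from compound 2 to compound 4, 1.1-fold (0.05 log units) apart, within the scatter of two such steps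

What the compounds shown leave open is whether any other group on that aromatic carbon, para to a large group, such as an amine or a carboxylic acid, would move the number in this assay beyond the scatter. With every step here lying within the scatter, they also leave open whether either of these two places can shift the number at all, as they reveal no change that does.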